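Bromo in Place of Trifluoromethoxy: What Compound 4 May Show

The source may report more compounds than this note shows. Statements on the series, on what has been measured and on what is new or still open speak of the compounds shown alone.

Compound 1 `O=C1/C(=C/c2ccccc2)CCc2ccc(O)cc21` gives 710 nM in a functional assay on RAW264.7 cells (Mus musculus) for inhibition; a higher number here means a weaker inhibitor, a lower number a stronger inhibitor.
Compound 2 `O=C1/C(=C/c2ccc(F)cc2)CCc2ccc(O)cc21` gives 840 nM.
Compound 3 `O=C1/C(=C/c2ccc(OC(F)(F)F)cc2)CCc2ccc(O)cc21` gives 980 nM.

These three compounds share one core and differ only in the group on the aromatic carbon of the outer ring. Compound 3 gives the largest of the three numbers, yet the steps of a 1.4-fold higher number from compound 1 to compound 3 (0.14 log units; within the scatter) and a 1.2-fold higher number from compound 2 to compound 3 (0.07 log units; within the scatter) both lie within the scatter, as does the step of a 1.2-fold higher number from compound 1 to compound 2 (0.07 log units; within the scatter); on these numbers, hydrogen, fluoro and trifluoromethoxy at that carbon are not told apart.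

Compound 4 `O=C1/C(=C/c2ccc(Br)cc2)CCc2ccc(O)cc21` has not been measured. The change from compound 3 is bromo in place of trifluoromethoxy on an aromatic carbon. Among the compounds with values here, no measured step swaps one halogen-bearing group for another directly, but every step recorded at this carbon stayed within the scatter, so the expected step of a 1.1-fold lower number from compound 3 to compound 4 (0.04 log units; within the scatter) is small and of no settled direction. Compound 4 is therefore estimated at 900 nM, with a range from 450 nM to 1800 nM.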

Compound 4, half-maximal inhibitory concentration: 800 nM
Estimate against measurement, compound 4: 1.1-fold (0.05 log units) above; the measured number falls inside the stated range.
By their numbers in this assay, from the lowest: compounds 1, 4, 2 and 3 (each within the scatter of the next).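

In this assay bromo proves to be a fourth group at this aromatic carbon that cannot be told apart from the others, with the steps from trifluoromethoxy (a 1.2-fold lower number from compound 3 to compound 4 (0.09 log units; within the scatter)), from fluoro (a 1.1-fold lower number from compound 2 to compound 4 (0.02 log units; within the scatter)) and from hydrogen (a 1.1-fold higher number from compound 1 to compound 4 (0.05 log units; within the scatter)) all lying within the scatter. Even the exchange of trifluoromethoxy, with its 5 heavy atoms and its hydrogen-bond acceptor, for the single heavy atom of bromo gives no readable difference, so hydrogen, fluoro, bromo and trifluoromethoxy remain unseparated at this carbon. No measurement at hand offers an explanation for how closely these compounds agree.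

Going by these compounds, whether an amine, a carboxylic acid or a longer chain at this carbon would carry the number beyond the scatter remains open. Also open, on these data alone, is whether bromo or trifluoromethoxy would behave the same way at another carbon of the outer ring.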